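Trifluoromethyl on the side-chain phenyl of compound 1

A few compounds are considered here, and "the series" means these few. Any claim that something is new, unique, unknown or untested is made for them only; others in the source may bear on it.

Measured so far:
compound 1, `Cc1cc(C(=O)O)ccc1CN1CCC[C@H](O[C@H](CO)c2ccccc2)[C@@H]1c1ccccc1`: 25000 nM
compound 2, `Cc1cc(C(=O)O)ccc1CN1CC[C@H](OC(CO)c2cc(Cl)cc(Cl)c2)[C@@H]1c1ccccc1`: 133000 nM
compound 3, `Cc1cc(C(=O)O)ccc1CN1CCC[C@H](O[C@H](CS(C)(=O)=O)c2cc(Cl)cc(Cl)c2)[C@@H]1c1ccccc1`: 330 nM

In an assay on isolated protein for activation of cGMP-dependent protein kinase 1 (Homo sapiens), read by ADP-Glo, with stated times of 30 min and 2 h, in the presence of a further agent that is not named here (a lower number here means that less compound is needed, a higher number that more compound is needed for the effect), compound 1 gives 25000 nM, the second highest of the three numbers. Compound 2 gives 133000 nM, a higher number, and the gap lies beyond the scatter. Compound 3 gives 330 nM, the lowest number of the set, again beyond the scatter. Compound 2 and compound 3 differ from compound 1 in more than one place, so no single change can be read off from these pairs.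

Compound 4, `Cc1cc(C(=O)O)ccc1CN1CCC[C@H](O[C@H](CO)c2cccc(C(F)(F)F)c2)[C@@H]1c1ccccc1`, is the next compound in the series. It differs from compound 1 by trifluoromethyl in place of hydrogen on an aromatic carbon. Within the data shown here, no measured pair shows this change on its own. The two substituted-phenyl compounds bring other changes with them, so their numbers give no clean guide. A modest lowering of the number is expected, perhaps not beyond the scatter, as a 2.1-fold lower number from compound 1 to compound 4 (0.32 log units; beyond the scatter). For compound 4 the expected value in this assay is 12000 nM, within 3000 nM to 50000 nM.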

Compound 4, half-maximal effective concentration: 4100 nM
Compound 4: middle estimate off by 2.9-fold (0.47 log units), on the high side; low and high end bracket the measured number.
By their numbers in this assay, from the lowest: compound 3; then compound 4; then compound 1; then compound 2.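

In this assay, among these compounds, the change from phenyl to 3-(trifluoromethyl)phenyl is the first change that can be read on its own, and it gives a 6.1-fold lower number from compound 1 to compound 4 (0.79 log units; beyond the scatter). The aromatic carbon meta to a large group therefore accepts trifluoromethyl, with its 4 heavy atoms, and the number falls beyond the scatter; compound 2 and compound 3 could not show this, as each differs from compound 1 in more than one place. No independent measurement accompanies this step, so the data give no account of what lies behind the lower number.

Open, going by these compounds, is whether a chlorine atom, a methoxy group or a nitrile on the same aromatic carbon would give a step of similar size, and whether trifluoromethyl on another carbon of this ring would match it. Among the compounds shown here, also open is whether the step carries over to a compound in which the hydroxymethyl arm gives way to the methylsulfonylmethyl arm of compound 3, since no measured pair shows that combination or isolates either change.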